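The source may hold more compounds than are shown below. What is called first, only, known or untested is meant among the compounds shown, and "the series" means these compounds.

Compound 1 `Cn1c(=O)c2c(nc(SCCc3ccc(Br)cc3)n2C)n(C)c1=O`: 108000 nM
Compound 2 `Cn1c(=O)c2c(nc([S+]([O-])CCc3ccc(Cl)cc3)n2C)n(C)c1=O`: 203000 nM
Compound 3 `Cn1c(=O)c2c(nc([S+]([O-])CCc3ccc(Br)cc3)n2C)n(C)c1=O`: 57300 nM

All three were tested in an assay on microsomes for inhibition of Amine oxidase [flavin-containing] A (Homo sapiens), read by fluorescence and spectrophotometry, with a stated time of 20 min; a lower number here means a stronger inhibitor, a higher number a weaker inhibitor. Compound 1 gives 108000 nM, a number that lies within the usual scatter of the numbers for compound 2 and for compound 3, so compound 1 cannot be set apart from either of them. Going by the values given here, the only step that clears the scatter is a 3.5-fold lower number from compound 2 to compound 3 (0.55 log units; beyond the scatter), a swap of one halogen for another.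

Compound 4 `Cn1c(=O)c2c(nc(SCc3cccc(Br)c3)n2C)n(C)c1=O` differs from compound 1 by 3-bromophenyl in place of 4-bromobenzyl on a saturated chain carbon bound to a sulfur. Among the compounds with values here, no measured step shortens the chain or moves the bromine, so the halogen swap offers no direct guide. With nothing pushing the expectation either way, compound 4 is expected to give about 120000 nM, in a range from 40000 nM to 400000 nM. The expected step is therefore a 1.1-fold higher number from compound 1 to compound 4 (0.05 log units; within the scatter), not beyond the scatter but with wide uncertainty.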

Compound 4, half-maximal inhibitory concentration: 37900 nM
For compound 4 the middle estimate is 3.2-fold (0.50 log units) above the measured one; measured number outside the range, below it.
By their numbers in this assay, from the lowest: compounds 4, 3, 1 and 2 (each within the scatter of the next, the first and the last beyond it).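

In this assay, the swap on a saturated chain carbon bound to a sulfur gives a 2.8-fold lower number from compound 1 to compound 4 (0.45 log units; beyond the scatter), which shows that the group at this place can shift the number beyond the scatter. The change from 4-bromobenzyl to 3-bromophenyl alters both the group's size and the bromine's location, so the step cannot be assigned to either alone. Nothing available explains the step. As far as these compounds go, it remains open how much each of those two differences contributes, and how a carboxylic acid or an amine on the aromatic ring in place of bromine would read.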